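The source may report more compounds than this note shows. Statements on the series, on what has been measured and on what is new or still open speak of the compounds shown alone.

Measured compounds:
Compound 1, `CC(C)n1c(=O)n(C(=O)NCC2CCNCC2)c2ccccc21`, 39.8 nM in an assay on HEK293 cells for displacement of a labelled ligand from 5-hydroxytryptamine receptor 4 (Homo sapiens), read by scintillation counting; on this read-out higher numbers stand for weaker inhibition and lower numbers for stronger inhibition
Compound 2, `COc1ccc2[nH]cc(C(=O)NCC3CCNCC3)c2c1`, 3980 nM in this assay
Compound 3, `CCN1CCC(NC(=O)c2cc(Cl)c(N)cc2OC)CC1`, 1000 nM in this assay

Among these three numbers compound 3 stands second highest in this assay: its neighbour is compound 2, whose number is higher by a gap beyond the usual scatter, and the furthest from it is compound 1, whose number is lower by a gap well beyond the scatter. Compound 4, `COc1cc(N)c(Cl)cc1C(=O)NC1CCN(CCCCCCCCO)CC1`, keeps the whole framework of compound 3 and differs from it in one place: 6-hydroxyhexyl in place of hydrogen on a saturated chain carbon, two bonds along the chain from an amine nitrogen in a ring. For the measured compounds named here, no pair of measured compounds differs by a change of this kind, so the data give no direct guide to its size or direction. The expectation stated here is that the number falls, that is that compound 4 is estimated to bind more tightly than compound 3, with the step of a 17-fold lower number from compound 3 to compound 4 (1.22 log units; beyond the scatter) judged to lie beyond the scatter. On that basis compound 4 is estimated at 60 nM in this assay, within a range from 10 nM to 400 nM.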

Compound 4, inhibition constant: 79.4 nM
Estimate against measurement, compound 4: 1.3-fold (0.12 log units) below, and the stated range covers the measured number.
By their numbers in this assay, from the lowest: compounds 1 and 4 (each within the scatter of the next); then compound 3; then compound 2.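

In this assay the change gives a 13-fold lower number from compound 3 to compound 4 (1.10 log units; beyond the scatter), the first step measured at this place, a saturated chain carbon two bonds along the chain from an amine nitrogen in a ring. For the compounds shown here, it shows that the framework of compound 3 takes a group as large as 6-hydroxyhexyl here and that the number falls rather than rises, which no earlier pair could show. Nothing measured here explains this step.

Going by these compounds, it remains open whether the chain or its hydroxyl carries the step: a plain hexyl group, a shorter chain such as 2-hydroxyethyl, or a longer chain ending in an amine or a carboxylic acid would separate the two. On these data alone, with a single step at one place, it is also open whether the same group would have a similar effect on the framework of compound 1 or compound 2.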